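The source may hold more compounds than are shown below. What is called first, only, known or untested is meant among the compounds shown, and "the series" means these compounds.

Working notes on a set of analogues sharing the core of compound 1, all tested in an assay on isolated protein for inhibition of 11-beta-hydroxysteroid dehydrogenase type 2 (Homo sapiens); on this read-out lower numbers stand for stronger inhibition and higher numbers for weaker inhibition. Compound 1 `Cn1c(-c2ccc(-c3cncnc3)cc2)nnc1C1(c2ccc(Cl)cc2)CCC1` carries a pyrimidin-5-yl group. In this assay compound 1 returns > 4000 nM, which is a limit of the assay and not a number. Compound 2 `Cn1c(-c2ccc(-c3cnccn3)cc2F)nnc1C1(c2ccc(Cl)cc2)CCC1` likewise returns > 4000 nM, again a limit rather than a measured value. Compound 3 `Cn1c(-c2ccc(C(N)=O)cc2Cl)nnc1C1(c2ccc(Cl)cc2)CCC1` gives > 4000 nM, once more a limit. Going by the values given here, the picture of the measured set is the limit of > 4000 nM in this assay, at which 3 of the 3 values shown sit, so no numbered value exists anywhere in it, no step between measured compounds can be sized, and where compound 1 stands relative to compounds 2 and 3 cannot be said beyond the shared limit.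

Compound 4 `Cn1c(-c2ccc(C(=O)NC(C)(C)C)cc2)nnc1C1(c2ccc(Cl)cc2)CCC1` is not yet measured. It differs from compound 1 in one place, ((tert-butyl)carbamoyl in place of pyrimidin-5-yl on an aromatic carbon), that is, (tert-butyl)carbamoyl in place of pyrimidin-5-yl on an aromatic carbon. With every shown value a limit, no measured step supports a direction for this change. The expected step that the limit leaves unreadable from compound 1 to compound 4 is none beyond the scatter, with compound 4 most likely again reported only as a limit. The estimate for compound 4 is accordingly 6000 nM, with a range from 2000 nM to 20000 nM.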

Compound 4, half-maximal inhibitory concentration: > 4000 nM
Compound 4 gave a limit, no number (the forecaster's own chance of this, stated with the estimate: 80%); the middle value does not contradict the limit.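

In this assay compound 4 gives > 4000 nM which is a limit of the assay and not a number. Going by these compounds alone, compound 1 also stands at a limit, so no step between compound 1 and compound 4 can be read: the limit of > 4000 nM in this assay, at which 4 of the 4 values shown sit. The compounds shown leave open how strongly any of them inhibits, and whether (tert-butyl)carbamoyl and pyrimidin-5-yl differ at all on this read-out.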